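Swapping the Nitrophenyl Group on an Acylurea Thiazole

A few compounds are considered here, and "the series" means these few. Any claim that something is new, unique, unknown or untested is made for them only; others in the source may bear on it.

Measured compounds:
Compound 1, `CN(C(=O)NC(=O)c1ccccc1F)c1nc(C(F)(F)F)c(C(=O)N/N=C/c2cc(C(F)(F)F)cc(C(F)(F)F)c2)s1`, gives 5.43 ug/mL in a functional assay on A549 cells (Homo sapiens) for inhibition, read by MTT assay, with a stated time of 72 h; on this read-out lower numbers stand for stronger inhibition and higher numbers for weaker inhibition.
Compound 2, `CN(C(=O)NC(=O)c1ccc([N+](=O)[O-])cc1)c1nc(C(F)(F)F)c(C(=O)N/N=C/c2ccc([N+](=O)[O-])cc2)s1`, gives 8.98 ug/mL.
Compound 3, `CNc1nc(C)c(C(=O)N/N=C/c2cc(C(F)(F)F)cc(C(F)(F)F)c2)s1`, gives > 100 ug/mL.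

The value of compound 3 is a limit of this assay, not a number; it sits at the limit of > 100 ug/mL in this assay, at which 1 of the 3 values shown sits. Among the two compounds with numbers, compound 2 has the higher one, but compound 1 is its nearest neighbour and the gap between them lies within the scatter, so no order between compound 1 and compound 2 can be read from these two values.

Compound 4, `CN(C(=O)NC(=O)c1ccc(Cl)c(Cl)c1)c1nc(C(F)(F)F)c(C(=O)N/N=C/c2ccc([N+](=O)[O-])cc2)s1`, has not yet been measured. It differs from compound 2 in one place: 3,4-dichlorophenyl in place of 4-nitrophenyl on a carbonyl carbon. Within the data shown here, no measured pair in this set differs by this kind of change, so there is no measured step to lean on. What can be said is that compound 1, which carries a different group on that same carbonyl carbon, gives 5.43 ug/mL, close to compound 2. On that basis the step from compound 2 to compound 4 is expected to be small, a 1.3-fold lower number from compound 2 to compound 4 (0.11 log units; within the scatter), not clearly beyond the scatter in either direction. Compound 4 is therefore estimated at 7 ug/mL, with a likely range from 2.5 ug/mL to 20 ug/mL.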

Compound 4, half-maximal inhibitory concentration: 6.44 ug/mL
The estimate for compound 4 lay 1.1-fold (0.04 log units) above the measured number; the range from low to high includes it.
By their numbers in this assay, from the lowest: compounds 1, 4 and 2 (each within the scatter of the next). At a limit, above all of these: compound 3.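

Among these compounds, compound 2 and compound 4 are the first pair here that differ in one place only, which gives a direct reading of the group on the carbonyl carbon whose other neighbour is an amide-type nitrogen. In this assay the change from 4-nitrophenyl to 3,4-dichlorophenyl gives a 1.4-fold lower number from compound 2 to compound 4 (0.14 log units; within the scatter) and so the two compounds cannot be told apart, even though the two groups have little in common beyond the six-membered aromatic ring of carbon: the hydrogen-bond acceptors of 4-nitrophenyl are gone, and two chlorine atoms stand in the new group. At this position, then, the read-out does not separate these two groups, but nothing measured here gives a reason for that.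

One pair cannot show how far this tolerance reaches, since both groups keep the aromatic ring on the carbonyl carbon. A small methyl group or a longer alkyl chain in place of that ring, or a ring carrying an amine or a carboxylic acid, could still shift the number well beyond the scatter or leave it unchanged.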